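Swapping the ring-nitrogen substituent: from ester-bearing chain to allyl

This account rests on a few compounds, and the source may have more. Where it says the series, first, only, none or still open, it means among the compounds named here.

Measured compounds:
- compound 1 `CCCC[C@H](NC(=O)[C@H](CCCCN)NC(=O)[C@H](CCCNC(=N)N)NC(=O)c1ccc(/C=C2\SC(=S)N(CCCC)C2=O)cc1)C(N)=O`: 1.61 10^-6 cm/s
- compound 2 `CCCCC(C(=O)OC)N1C(=O)/C(=C/c2ccc(C(=O)N[C@@H](CCCNC(=N)N)C(=O)N[C@@H](CCCCN)C(=O)N[C@@H](CCCC)C(N)=O)cc2)SC1=S`: 0.87 10^-6 cm/s

In an ADME assay for permeability, using PAMPA (on this read-out lower numbers stand for lower permeability and higher numbers for higher permeability), compound 2 gives the lowest of the two numbers, yet the step is a 1.9-fold lower number from compound 1 to compound 2 (0.27 log units; within the scatter), so the two values cannot be told apart. Compound 3 `C=CCN1C(=O)/C(=C/c2ccc(C(=O)N[C@@H](CCCNC(=N)N)C(=O)N[C@@H](CCCCN)C(=O)N[C@@H](CCCC)C(N)=O)cc2)SC1=S` differs from compound 2 by allyl in place of 1-(methoxycarbonyl)pentyl on an amide-type nitrogen in a ring. Among the measured compounds shown here, the only step that bears on this change is a 1.9-fold lower number from compound 1 to compound 2 (0.27 log units; within the scatter), in which a larger group on the same nitrogen moved the number only within the scatter. For compound 3 a step of a 1.5-fold higher number from compound 2 to compound 3 (0.17 log units; within the scatter) in this assay is therefore expected, because a 1.9-fold lower number from compound 1 to compound 2 (0.27 log units; within the scatter) stayed small. Compound 3 is estimated at 1.3 10^-6 cm/s, with a range of 0.6 10^-6 cm/s to 2.8 10^-6 cm/s.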

Compound 3, apparent permeability: 0.42 10^-6 cm/s
Beside the measured number, compound 3's estimate is 3.1-fold (0.49 log units) above it, and the stated range ends above it.
By their numbers in this assay, from the lowest: compound 3; then compounds 2 and 1 (each within the scatter of the next).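

In this assay, allyl on this amide-type nitrogen in a ring gives a 2.1-fold lower number from compound 2 to compound 3 (0.32 log units; beyond the scatter) and a 3.8-fold lower number from compound 1 to compound 3 (0.58 log units; beyond the scatter). Both steps lie beyond the scatter, which the earlier pair did not show, so the group on this nitrogen can move the number measurably. Nothing available explains these steps. Whether the double bond of allyl or its shorter length matters stays open, since the compounds shown do not separate the two. Also open, as far as these compounds go, is how an amine, a carboxylic acid or a longer chain on this nitrogen would read.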